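Swapping the Benzyl Group on Two Related Cores

The source may report more compounds than this note shows. Statements on the series, on what has been measured and on what is new or still open speak of the compounds shown alone.

Measured compounds in a functional assay on HL-60 cells (Homo sapiens) for cytotoxicity, read by MTT assay, with a stated time of 48 h; a lower number here means a stronger inhibitor, a higher number a weaker inhibitor:
compound 1 `Cc1ccc(Cn2c(/C=C3\SC(=S)N(CC(=O)O)C3=O)nc3ccc(Cl)cc32)cc1`, 2840 nM
compound 2 `Cc1ccc(Cn2c(/C=C3\SC(=S)NC3=O)nc3ccccc32)cc1`, 2660 nM
compound 3 `O=C(O)CN1C(=O)/C(=C/c2nc3ccc(Cl)cc3n2Cc2ccccc2F)SC1=S`, 5230 nM

Compound 1 and compound 2 carry different cores; the difference between the two cores is not broken down here. Compound 3 is made from compound 1 by one change, (2-fluorophenyl in place of 4-methylphenyl on a saturated chain carbon bound to an aromatic nitrogen), and in this assay that change gave a 1.8-fold higher number from compound 1 to compound 3 (0.27 log units; within the scatter), a step that stays within the usual scatter of repeated measurements. Compound 2 and compound 1 likewise lie within the scatter of each other, so no order can be read between them.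

Compound 4 `O=C1NC(=S)S/C1=C\c1nc2ccccc2n1Cc1ccccc1F` has not been measured. It stands to compound 2 exactly as compound 3 stands to compound 1: the change is 2-fluorophenyl in place of 4-methylphenyl on a saturated chain carbon bound to an aromatic nitrogen, the same change on the same place, only on the other core.

For the measured compounds named here, because the one prior example of this change, a 1.8-fold higher number from compound 1 to compound 3 (0.27 log units; within the scatter), was small, the step from compound 2 to compound 4 is expected to be of about that size, a 1.7-fold higher number from compound 2 to compound 4 (0.23 log units; within the scatter). Compound 4 is therefore estimated at 4500 nM in this assay, with a likely range from 2000 nM to 10000 nM.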

Compound 4, half-maximal inhibitory concentration: 8420 nM
Compound 4: middle estimate off by 1.9-fold (0.27 log units), on the low side; the range from low to high includes it.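

In this assay, putting 2-fluorophenyl in place of 4-methylphenyl on the second core gave a 3.2-fold higher number from compound 2 to compound 4 (0.50 log units; beyond the scatter). Set beside the same change on the first core, the number rises both times, and the two steps cannot be told apart in size: the same change on two cores in this assay, a 1.8-fold higher number (0.27 log units; within the scatter) from compound 1 to compound 3 and a 3.2-fold higher number (0.50 log units; beyond the scatter) from compound 2 to compound 4, 1.7-fold (0.24 log units) apart, within the scatter of two such steps This shows that the change went the same way on both cores, with no sign that the core altered its size; it does not show that the change would act alike on a third core, and with only two pairs, one of them within the scatter, the agreement remains thin.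

The compounds shown carry only 4-methylbenzyl and 2-fluorobenzyl on the saturated chain carbon bound to an aromatic nitrogen, so it stays open how a plain benzyl group, a longer chain such as phenylethyl, or a chain ending in an amine would fare. Going by these compounds, whether fluorine or the loss of the methyl group drives the step also stays open.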